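Hydroxy for Chloro on the Shared Core: Compound 4

A few compounds are considered here, and "the series" means these few. Any claim that something is new, unique, unknown or untested is made for them only; others in the source may bear on it.

Three analogues of one shared core have been measured in an assay on cells for displacement of a labelled ligand from adenosine receptor A2b (Homo sapiens), read by scintillation counting and radioligand binding, with a stated time of 30 min, tested at 10 uM; on this read-out higher numbers stand for more inhibition at the one concentration tested (going by the name of the read-out) and lower numbers for less inhibition. Compound 1 `Clc1ccc(-c2nc(N3CCCCC3)c3nc[nH]c3n2)cc1Cl` gives 0.7%, compound 2 `Clc1ccc(-c2nc(N3CCCCC3)c3nc[nH]c3n2)cc1` gives 1.4%, and compound 3 `CN1CCN(c2nc(-c3ccc(Cl)cc3)nc3[nH]cnc23)CC1` gives 6.2%, so compound 2 sits among numbers that all lie within the scatter of one another. The two known steps, a number 0.7 percentage points higher from compound 1 to compound 2 (within the scatter) and a number 4.8 percentage points higher from compound 2 to compound 3 (within the scatter), both stay within the scatter. Compound 4 `Oc1ccc(-c2nc(N3CCCCC3)c3nc[nH]c3n2)cc1` differs from compound 2 by hydroxy in place of chloro on an aromatic carbon. For the measured compounds named here, no measured step touches this change; the two steps on hand merely show that neither removing a chloro nor swapping the cyclic amine moved this assay beyond its scatter. Compound 4 is therefore expected to show a number 1.6 percentage points higher from compound 2 to compound 4 (within the scatter), and its estimated value is 3%, between -7% and 15%.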

Compound 4, a percentage reported as inhibition, at one concentration (the size of the read-out at that concentration, not a potency): > 80%
Compound 4 gave a limit, no number; the forecaster's own chance of this, stated with the estimate: 0%; middle value at least 77 percentage points from the limit.
By their numbers in this assay, from the lowest: compounds 1, 2 and 3 (each within the scatter of the next). At a limit, above all of these: compound 4.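

For the compounds shown here, on an aromatic carbon para to a large group, hydroxy in place of chloro gives a number at least 78.6 percentage points higher from compound 2 to compound 4 (beyond the scatter) and is the first change here to leave the scatter. In this assay compound 4 reads only as a limit: the limit of > 80% in this assay, at which 1 of the 4 values shown sits. Going by these compounds alone, this position therefore responds strongly to the group placed on it, which the earlier steps, all within the scatter, gave no sign of.

On these data alone, what stays open is whether an amine or a carboxylic acid in the same place would behave like hydroxy. Also open, as far as these compounds go, is whether 4-hydroxyphenyl keeps this reading with 4-methylpiperazin-1-yl in place of piperidin-1-yl.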